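Compound 3 to compound 4: an exchange on the side chain

A few compounds are considered here, and "the series" means these few. Any claim that something is new, unique, unknown or untested is made for them only; others in the source may bear on it.

Going by the values given here, in a functional assay on HepG2 cells (Homo sapiens) for antiproliferative activity, read by CCK-8 assay, with a stated time of 48 h (on this read-out lower numbers stand for stronger inhibition and higher numbers for weaker inhibition), compound 3 (`COc1ccc(/C=C\c2cc(OC)c(OC)c(OC)c2)cc1OCc1ccc(CNCCN(C)C)cc1`) gives 4400 nM, the only value in this small set that is an actual number. Compound 1 (`COc1ccc(/C=C\c2cc(OC)c(OC)c(OC)c2)cc1OCc1ccc(CN[C@H](C(=O)O)[C@H](C)O)cc1`) gives > 10000 nM, which is a limit of the assay and not a number. Compound 2 (`COc1ccc(/C=C\c2cc(OC)c(OC)c(OC)c2)cc1OCc1ccc(CN2CC(C(=O)O)C2)cc1`) gives > 10000 nM, which is likewise a limit.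

Compound 4 (`COc1ccc(/C=C\c2cc(OC)c(OC)c(OC)c2)cc1OCc1ccc(CN2CC[C@@H](O)C2)cc1`) carries 3-hydroxypyrrolidin-1-yl in place of (2-(dimethylamino)ethyl)amino on a saturated chain carbon bound to an aromatic carbon.

Among the compounds with values here, two measured steps bear on this change: an at least 2.2-fold lower number from compound 1 to compound 3 (0.35 log units; beyond the scatter), and an at least 2.2-fold lower number from compound 2 to compound 3 (0.35 log units; beyond the scatter). Going by these compounds, both arrive at compound 3 by bringing in the group that now leaves, and both are bounded by limits, so their true sizes remain unknown. Compound 4 gives that group up, but it regains neither of the carboxy-bearing groups of compound 1 and compound 2. Within the data shown here, no measured compound carries the entering group, so the evidence is indirect, and only a small move towards weaker inhibition is expected, within the scatter. The expected change is a 1.4-fold higher number from compound 3 to compound 4 (0.13 log units; within the scatter). For compound 4 the estimated value is 6000 nM, with an expected range from 2000 nM to 15000 nM.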

Compound 4, half-maximal inhibitory concentration: 6200 nM
For compound 4 the middle estimate is 1.0-fold (0.01 log units) below the measured one; the range from low to high includes it.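

In this assay, the step of a 1.4-fold higher number from compound 3 to compound 4 (0.15 log units; within the scatter) shows that, on a saturated chain carbon bound to an aromatic carbon, the open (2-(dimethylamino)ethyl)amino can give way to the ring of 3-hydroxypyrrolidin-1-yl with no change beyond the scatter. The earlier compounds shown here could not show this, as compound 3 alone had a number, so the dimethylamino group could have seemed necessary for a measurable value, whereas compound 4 reaches one without it. The steps of an at least 1.6-fold lower number from compound 2 to compound 4 (0.20 log units; that floor lies within the scatter) and an at least 1.6-fold lower number from compound 1 to compound 4 (0.20 log units; that floor lies within the scatter) are floors that lie within the scatter, set by a limit of the assay and not by a number: the limit of > 10000 nM in this assay, at which 2 of the 4 values shown sit.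

The compounds shown do not separate the part played by the ring from that of its hydroxy group, which a plain pyrrolidine or an open-chain hydroxyalkyl amine would address. They also leave open how the other stereoisomer of 3-hydroxypyrrolidin-1-yl or a longer chain carrying the dimethylamino group would read at this place.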